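The source may report more compounds than this note shows. Statements on the series, on what has been measured and on what is new or still open speak of the compounds shown alone.

Three compounds share one core and differ only in the group carried on one aromatic carbon of the fused ring system. Compound 1 `COC(=O)[C@@]1(C)CCC=C2[C@@H]1CC[C@@H](C)[C@]2(C)Cc1c(C)[nH]c2ccc(C)cc12` carries a methyl there and in a functional assay on HBL-100 cells (Homo sapiens) for inhibition, read by sulforhodamine B assay, with a stated time of 48 h (on this read-out lower numbers stand for stronger inhibition of growth and higher numbers for weaker inhibition of growth), compound 1 gives 25000 nM. Compound 2 `COC(=O)[C@@]1(C)CCC=C2[C@@H]1CC[C@@H](C)[C@]2(C)Cc1c(C)[nH]c2ccc(Br)cc12` carries a bromo and in this assay compound 2 gives 15000 nM. Compound 3 `COC(=O)[C@@]1(C)CCC=C2[C@@H]1CC[C@@H](C)[C@]2(C)Cc1c(C)[nH]c2ccc(Cl)cc12` carries a chloro and in this assay compound 3 gives 15000 nM, level with compound 2 at the digits shown.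

Every step among these three is small: a 1.7-fold lower number from compound 1 to compound 2 (0.22 log units; within the scatter), a 1.7-fold lower number from compound 1 to compound 3 (0.22 log units; within the scatter) and no change at the digits printed from compound 2 to compound 3 (within the scatter). Three different groups at this one position thus give numbers that cannot be told apart within the usual scatter.

Compound 4 `COC(=O)[C@@]1(C)CCC=C2[C@@H]1CC[C@@H](C)[C@]2(C)Cc1c(C)[nH]c2ccc(C(F)(F)F)cc12` is the next member of the set, made from compound 3 by the change (trifluoromethyl in place of chloro on an aromatic carbon). Since the three measured swaps at this same carbon all stayed within the scatter, the expectation for this fourth swap is likewise no step beyond the scatter in this assay, in either direction, written as no change at the digits printed from compound 3 to compound 4 (within the scatter). For compound 4 the estimated value in this assay is therefore 15000 nM, with a likely range from 7000 nM to 35000 nM.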

Compound 4, concentration for 50% growth inhibition: 16000 nM
Compound 4: middle estimate off by 1.1-fold (0.03 log units), on the low side; low and high end bracket the measured number.
By their numbers in this assay, from the lowest: compounds 2, 3, 4 and 1 (each within the scatter of the next).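

In this assay, trifluoromethyl gives a 1.1-fold higher number from compound 3 to compound 4 (0.03 log units; within the scatter) and a 1.1-fold higher number from compound 2 to compound 4 (0.03 log units; within the scatter) and also a 1.6-fold lower number from compound 1 to compound 4 (0.19 log units; within the scatter) so its step is within the scatter whichever of the three earlier groups it replaces. This is the first swap shown at this aromatic carbon in which a group of 4 heavy atoms enters, whereas methyl, bromo and chloro were compared only with one another, so the four groups now shown cannot be told apart on this read-out, and the position tolerates this larger change without a step beyond the scatter. Nothing measured here explains why these groups read alike.

On these data alone, it remains open whether a group of another kind on this same carbon, such as an amine, a carboxylic acid or a longer chain, would give a step beyond the scatter. As far as these compounds go, it also remains open whether this flat picture would hold if the shared core were changed in another place, since all four compounds differ only at this one carbon.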